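Replacing the Carboxy-Bearing Group of Compound 3

This account rests on a few compounds, and the source may have more. Where it says the series, first, only, none or still open, it means among the compounds named here.

Measured in a functional assay on B16-F10 cells (Mus musculus) for antiproliferative activity, read by CCK-8 assay, with a stated time of 48 h; on this read-out lower numbers stand for stronger inhibition and higher numbers for weaker inhibition:
Compound 1, `COc1ccc(/C=C\c2cc(OC)c(OC)c(OC)c2)cc1OCc1ccc(CN2C[C@H](O)C[C@@H]2C(=O)O)cc1`: > 10000 nM (a limit)
Compound 2, `COc1ccc(/C=C\c2cc(OC)c(OC)c(OC)c2)cc1OCc1ccc(CN2CCCC[C@H]2C(=O)O)cc1`: > 10000 nM (a limit)
Compound 3, `COc1ccc(/C=C\c2cc(OC)c(OC)c(OC)c2)cc1OCc1ccc(CN[C@H](C(=O)O)[C@H](C)O)cc1`: > 10000 nM (a limit)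

Compound 3 gives only a limit and no number, > 10000 nM. It shares this position with the other two measured compounds: the limit of > 10000 nM in this assay, at which 3 of the 3 values shown sit.

The next compound is compound 4, `COc1ccc(/C=C\c2cc(OC)c(OC)c(OC)c2)cc1OCc1ccc(CO)cc1`. The change is hydroxy in place of (1-carboxy-2-hydroxypropyl)amino on a saturated chain carbon bound to an aromatic carbon, which in words is hydroxy in place of (1-carboxy-2-hydroxypropyl)amino on a saturated chain carbon bound to an aromatic carbon. Compound 4 is the only one of the four without a carboxy group.

Among the measured compounds shown here, three measured steps bear on this change: a step that the two limits leave unreadable from compound 1 to compound 2, a step that the two limits leave unreadable from compound 1 to compound 3 and a step that the two limits leave unreadable from compound 2 to compound 3. None of them has a readable size, so none can be carried over as a number. For the measured compounds named here, they show only that exchanging one carboxy-bearing group for another left each compound at a limit in this assay.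

A move toward stronger inhibition is therefore expected, though its size is poorly fixed and compound 4 may also stay at the limit. The expected step is an at least 12-fold lower number from compound 3 to compound 4 (1.09 log units; beyond the scatter). For compound 4 the estimated value is 800 nM, with an expected range from 50 nM to 10000 nM.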

Compound 4, half-maximal inhibitory concentration: 6600 nM
Compound 4: the middle estimate sits 8.3-fold (0.92 log units) below what was measured; measured number inside the range.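

In this assay, compound 4 is the only compound shown that gives a number rather than a limit, so with hydroxy on the saturated chain carbon bound to an aromatic carbon, the shared core reaches a readable value, which none of the three carboxy-bearing groups does: the limit of > 10000 nM in this assay, at which 3 of the 4 values shown sit.

Each comparison with compound 4 gives only a floor and not a size: an at least 1.5-fold lower number from compound 3 to compound 4 (0.18 log units; that floor lies within the scatter), an at least 1.5-fold lower number from compound 2 to compound 4 (0.18 log units; that floor lies within the scatter), and an at least 1.5-fold lower number from compound 1 to compound 4 (0.18 log units; that floor lies within the scatter). Since all three floors lie within the scatter, the result does not establish a clear gain over the carboxy-bearing compounds, and the steps among those three compounds still cannot be read.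

The compounds shown leave open how far the values of the three carboxy-bearing compounds lie from that of compound 4, and whether the carboxy group, the amine nitrogen, or the two together set the outcome at this place. A methyl ester in place of the carboxylic acid, or a simple primary amine in place of the hydroxy, would bear on that question in this assay.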